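Compound 4: hydroxy in place of fluoro

This account rests on a few compounds, and the source may have more. Where it says the series, first, only, none or still open, it means among the compounds named here.

Compound 3 (`O=C(NNc1c(Br)cccc1Br)c1ccc(F)cc1`) gives > 100000 nM in a toxicity assay on MDCK cells (Canis lupus familiaris) for cytotoxicity, read by CCK-8 assay, with a stated time of 48 h (on this read-out lower numbers stand for higher toxicity in this test and higher numbers for lower toxicity in this test), and this is a limit, not a number. Compound 1 (`O=C(NNc1c(Br)cccc1Br)c1ccc(OCC(F)(F)F)cc1`) gives > 100000 nM in the same read-out, also a limit. Compound 2 (`N#Cc1ccc(C(=O)NNc2c(Br)cccc2Br)cc1`) gives > 100000 nM here, again a limit. The whole measured set therefore rests on one boundary (the limit of > 100000 nM in this assay, at which 3 of the 3 values shown sit).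

Compound 4 (`O=C(NNc1c(Br)cccc1Br)c1ccc(O)cc1`) differs from compound 3 by hydroxy in place of fluoro on an aromatic carbon.

Three measured steps also exchange groups on an aromatic carbon (a step that the two limits leave unreadable from compound 1 to compound 2) (a step that the two limits leave unreadable from compound 1 to compound 3) (a step that the two limits leave unreadable from compound 2 to compound 3). None of them gives a size, so they offer no measured basis for a direction. They show only that 2,2,2-trifluoroethoxy, cyano and fluoro all leave the read-out at the limit. No step beyond the scatter is expected in this assay, and the most likely report is another limit.

The expected change is small (a step that the limit leaves unreadable from compound 3 to compound 4). The estimated value for compound 4 is 130000 nM, with an expected range of 40000 nM to 400000 nM.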

Compound 4, half-maximal cytotoxic concentration: > 100000 nM
Compound 4: no number, only a limit (the forecaster's own chance of this, stated with the estimate: 85%); the middle value is on the limit's open side.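

No new step can be read among compound 1, compound 2, compound 3 and compound 4, as all four results remain limits: the limit of > 100000 nM in this assay, at which 4 of the 4 values shown sit.

The compounds shown leave open whether hydroxy, fluoro, cyano and 2,2,2-trifluoroethoxy differ at all in this assay, and at what concentration any of the four would become toxic.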